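Butyl in Place of a Dimethylamino Tail on a Shared Core

This account rests on a few compounds, and the source may have more. Where it says the series, first, only, none or still open, it means among the compounds named here.

Measured so far:
compound 1, `CN(C)CCCNc1nc(NCc2ccco2)c2ccccc2n1`: "not determined" (no result reported)
compound 2, `Cc1cccc(N2CCN(CCCNc3nc(NCc4ccco4)c4ccccc4n3)CC2)c1C`: 95.9%

On these data alone, compound 1 has no result in a functional assay on MCF7 cells (Homo sapiens) for cytotoxicity, read by MTT assay, with a stated time of 2 days, tested at 10 uM (on this read-out higher numbers stand for more inhibition at the one concentration tested (going by the name of the read-out) and lower numbers for less inhibition), so where it stands on the numbers is unknown. In this assay compound 2 gives 95.9%. Compound 3 is `CCCCNc1nc(NCc2ccco2)c2ccccc2n1`; it differs from compound 1 by methyl in place of dimethylamino on a saturated chain carbon, three bonds along the chain from a nitrogen on an aromatic ring. Within the data shown here, no measured pair shows this change, so its size cannot be read from the data; with only compound 2 as a reference, a step of modest size downward is expected in this assay, with a wide uncertainty. Compound 3 is expected to give 60%, in the range 25% to 92%.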

Compound 3, a percentage reported as inhibition, at one concentration (the size of the read-out at that concentration, not a potency): 66.7%
Compound 3: the middle estimate sits 6.7 percentage points below what was measured; measured number inside the range.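

In this assay, among these compounds, compound 1 has no number, so no step to compound 3 can be read. What replacing 3-(dimethylamino)propyl with butyl does to the read-out stays open, and no measurement shown offers an explanation.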